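Non-aromatic ring replaces chloromethylpyridyl amide: compound 4

A few compounds are considered here, and "the series" means these few. Any claim that something is new, unique, unknown or untested is made for them only; others in the source may bear on it.

Compound 3 `CCCC(=O)N1CCC(NS(=O)(=O)c2ccc(NC(=O)c3cc(C)nc(Cl)c3)c3ccccc23)CC1` gives 43.9 nM in an in vitro functional assay on CHO/Galpha16 cells for antagonist activity at C-C chemokine receptor type 8 (Homo sapiens), read by FLIPR (a lower number here means a stronger inhibitor, a higher number a weaker inhibitor), and holds the second highest of the three numbers: compound 1 `CCCC(=O)N1CCC(NS(=O)(=O)c2ccc(NC(=O)CC3CCCC3)c3ccccc23)CC1` gives 145 nM and compound 2 `CCCC(=O)N1CCC(NS(=O)(=O)c2ccc(NC(=O)c3cccc(C)c3)c3ccccc23)CC1` gives 5.1 nM. Compound 4 `CCCC(=O)N1CCC(NS(=O)(=O)c2ccc(NC(=O)C3CCC3)c3ccccc23)CC1` carries cyclobutyl in place of 2-chloro-6-methylpyridin-4-yl on a carbonyl carbon. For the measured compounds named here, two measured steps bear on this change: a 3.3-fold lower number from compound 1 to compound 3 (0.52 log units; beyond the scatter) and a 28-fold lower number from compound 1 to compound 2 (1.45 log units; beyond the scatter), each moving from a non-aromatic group to an aromatic one and each lowering the number. Compound 4 goes the other way, back to a non-aromatic ring, so a modest rise in this assay is expected, roughly the reverse of the first of those steps. Compound 4 is therefore estimated at 150 nM, with a range of 50 nM to 450 nM. The expected step is a 3.4-fold higher number from compound 3 to compound 4 (0.53 log units; beyond the scatter), landing close to the number of compound 1.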

Compound 4, half-maximal inhibitory concentration: 57.9 nM
Compound 4: the middle estimate sits 2.6-fold (0.41 log units) above what was measured; the range from low to high includes it.
By their numbers in this assay, from the lowest: compound 2; then compounds 3 and 4 (each within the scatter of the next); then compound 1.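

In this assay, an aromatic ring is not needed for a number in this range on this carbonyl carbon: cyclobutyl and 2-chloro-6-methylpyridin-4-yl are not separated (a 1.3-fold higher number from compound 3 to compound 4 (0.12 log units; within the scatter)). The two non-aromatic groups do differ (a 2.5-fold lower number from compound 1 to compound 4 (0.40 log units; beyond the scatter)), while 3-methylphenyl remains clearly apart from cyclobutyl (an 11-fold higher number from compound 2 to compound 4 (1.06 log units; beyond the scatter)), so the aromatic or non-aromatic label alone does not order the series. Nothing available explains these differences. Open, from the compounds shown here alone, is whether unsubstituted phenyl or cyclohexyl on the same carbonyl carbon would fall nearer compound 2 or compound 4.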